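Phenylhydrazine ring substituents and paw edema inhibition

The source may report more compounds than this note shows. Statements on the series, on what has been measured and on what is new or still open speak of the compounds shown alone.

Measured compounds:
compound 1 `CC(=O)c1c(NNc2ccccc2)cc(C)oc1=O` 52%
compound 2 `CC(=O)c1c(NNc2ccc(Br)cc2)cc(C)oc1=O` 18.6%
compound 3 `COc1ccc(NNc2cc(C)oc(=O)c2C(C)=O)cc1` 24.5%

The three compounds share one core and differ only on the six-membered aromatic ring of carbon only. In a functional assay on the whole organism for inhibition, with Rattus norvegicus as the target, read by paw edema, with a stated time of 4 h, at a dose of 50 mg/kg (on this read-out higher numbers stand for more inhibition at the one dose given (going by the name of the read-out) and lower numbers for less inhibition), compound 1 gives 52%. Compound 2 has the lowest of the three numbers; its gap to compound 3 is within the scatter, so no order between those two can be read, while its gap to compound 1 is beyond it: a number 33.4 percentage points lower from compound 1 to compound 2 (beyond the scatter). Compound 3 likewise lies below compound 1, a number 27.5 percentage points lower from compound 1 to compound 3 (beyond the scatter), and a number 5.9 percentage points higher from compound 2 to compound 3 (within the scatter).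

Compound 4 `CC(=O)c1c(NNc2ccc([N+](=O)[O-])cc2)cc(C)oc1=O` is not yet measured. It differs from compound 2 by nitro in place of bromo on an aromatic carbon. Among the measured compounds shown here, no measured step replaces bromo with nitro. The step that bears on it most is the exchange of one ring group for another, a number 5.9 percentage points higher from compound 2 to compound 3 (within the scatter), which stayed within the scatter; both groups placed on that ring lowered the number against compound 1. A step within the scatter is therefore expected, a number 3.4 percentage points higher from compound 2 to compound 4 (within the scatter). Compound 4 is estimated at 22%, between 8% and 40%.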

Compound 4, a percentage reported as inhibition, in the whole organism at one dose (the size of the read-out at that dose, not a potency): 44.1%
Compound 4: middle estimate off by 22.1 percentage points, on the low side, and the stated range ends below it.
By their numbers in this assay, from the lowest: compounds 2 and 3 (each within the scatter of the next); then compounds 4 and 1 (each within the scatter of the next).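

A group on this aromatic carbon, para to a large group, does not by itself cost inhibition: with nitro in place of hydrogen there is a number 7.9 percentage points lower from compound 1 to compound 4 (within the scatter) and no change can be read, whereas bromo and methoxy both fell beyond the scatter against compound 1. Exchanging one ring group for another is also not silent, as nitro in place of bromo gives a number 25.5 percentage points higher from compound 2 to compound 4 (beyond the scatter) and nitro in place of methoxy gives a number 19.6 percentage points higher from compound 3 to compound 4 (beyond the scatter) on the same carbon, so the earlier step within the scatter held only for the bromo and methoxy pair. No measured data on the compounds account for this difference between the groups.

Still open, going by these compounds, is whether the result is particular to nitro or is shared by other groups on this carbon, such as a nitrile, an amine or a carboxylic acid.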